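The source may report more compounds than this note shows. Statements on the series, on what has been measured and on what is new or still open speak of the compounds shown alone.

Series values:
compound 1 `Cc1cc(Nc2cc(N3CCN(C)CC3)nc(Nc3ccc(S(N)(=O)=O)cc3)n2)n[nH]1`: 1210 nM
compound 2 `Cc1cc(Nc2cc(N3CCN(C)CC3)nc(Nc3ccc([N+](=O)[O-])cc3)n2)n[nH]1`: 84.4 nM
compound 3 `Cc1cc(Nc2cc(N3CCN(C)CC3)nc(Nc3ccc(Cl)cc3)n2)n[nH]1`: 138 nM

In a functional assay on MDA-MB-231 cells (Homo sapiens) for antiproliferative activity, read by CCK-8 assay, with a stated time of 72 h (on this read-out higher numbers stand for weaker inhibition and lower numbers for stronger inhibition), compound 3 gives 138 nM, the middle of the three numbers. It lies within the scatter of one neighbour, a 1.6-fold higher number from compound 2 to compound 3 (0.21 log units; within the scatter), and well clear of the other, an 8.8-fold lower number from compound 1 to compound 3 (0.94 log units; beyond the scatter).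

The next entry is compound 4 `COc1cccc(Nc2nc(Nc3cc(C)[nH]n3)cc(N3CCN(C)CC3)n2)c1`, with 3-methoxyphenyl in place of 4-chlorophenyl on a nitrogen on an aromatic ring.

Among the measured compounds shown here, no measured step involves 3-methoxyphenyl, so the evidence is indirect. The measured changes are on an aromatic carbon. Swapping nitro and chloro made no difference beyond the scatter, as a 1.6-fold higher number from compound 2 to compound 3 (0.21 log units; within the scatter) shows. Only the sulfamoyl compound stands apart, with a 14-fold lower number from compound 1 to compound 2 (1.16 log units; beyond the scatter) as the large step. Compound 4 has no sulfamoyl group, so that large step offers little guidance, and compound 3 at 138 nM is the better anchor.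

A small rise, not beyond the scatter, is expected: a 1.4-fold higher number from compound 3 to compound 4 (0.16 log units; within the scatter). For compound 4 the estimated value is 200 nM, with an expected range of 70 nM to 600 nM.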

Compound 4, half-maximal inhibitory concentration: 240 nM
Compound 4: middle estimate off by 1.2-fold (0.08 log units), on the low side, and the stated range covers the measured number.
By their numbers in this assay, from the lowest: compounds 2, 3 and 4 (each within the scatter of the next, the first and the last beyond it); then compound 1.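

3-methoxyphenyl is the first group at this position that is not a 4-substituted phenyl, and in this assay it cannot be told apart from 4-chlorophenyl (a 1.7-fold higher number from compound 3 to compound 4 (0.24 log units; within the scatter)). It does separate modestly from 4-nitrophenyl (a 2.8-fold higher number from compound 2 to compound 4 (0.45 log units; beyond the scatter)), although 4-chlorophenyl and 4-nitrophenyl themselves lie within the scatter of each other, so the three groups form a graded run rather than one tight cluster. Compound 1 remains apart from all three others, including the new entry (a 5.0-fold lower number from compound 1 to compound 4 (0.70 log units; beyond the scatter)), and no measurement in hand accounts for any of these differences.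

Compound 4 changes both the group and where it sits on the phenyl ring, so the two changes cannot be separated without 4-methoxyphenyl or 3-chlorophenyl at this position. Also open, from the compounds shown here alone, is how a carboxylic acid, an aminomethyl group or a methylsulfonyl group on that phenyl ring would read.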